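The compounds below may be only part of what the source reports. "The series", "measured", "known", "first", "only" and "open" are said of these compounds alone.

Compound 3, `Cc1cccc(Cc2cc(N3CCc4c(C(=O)NCCO)cccc43)ncn2)c1`: 90 nM
Compound 1, `O=C(NCCO)c1cccc2c1CCN2c1cc(Cc2cccc(C(F)(F)F)c2)ncn1`: 101 nM
Compound 2, `O=C(NCCO)c1cccc2c1CCN2c1cc(Cc2ccccc2C(F)(F)F)ncn1`: 711 nM

In a functional assay on HEK293 cells for agonist activity at G-protein coupled receptor 52 (Homo sapiens), read by cAMP accumulation, with a stated time of 15 min (a lower number here means that less compound is needed, a higher number that more compound is needed for the effect), compound 3 gives 90 nM, the lowest of the three numbers, but its gap to compound 1 is within the scatter and only compound 2 sits clearly apart. Compound 4, `O=C(NCCO)c1cccc2c1CCN2c1cc(Cc2cccc(OC(F)(F)F)c2)ncn1`, has not yet been measured. It is reached from compound 3 by one change: trifluoromethoxy in place of methyl on an aromatic carbon.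

Among the compounds with values here, the step that bears most directly on this change is the one between compound 1 and compound 3, which swaps trifluoromethyl for methyl at the same place: a 1.1-fold lower number from compound 1 to compound 3 (0.05 log units; within the scatter). Two quite different groups on that carbon thus gave numbers that cannot be told apart. The other two steps, a 7.0-fold higher number from compound 1 to compound 2 (0.85 log units; beyond the scatter) and a 7.9-fold lower number from compound 2 to compound 3 (0.90 log units; beyond the scatter), involve moving the group to a different carbon of the ring and so speak to position rather than to the group itself. Trifluoromethoxy is larger than either methyl or trifluoromethyl, so a small rise in the number seems possible, but the evidence points to a step from compound 3 to compound 4 that is expected to stay within the scatter: a 1.4-fold higher number from compound 3 to compound 4 (0.16 log units; within the scatter). Compound 4 is therefore estimated at 130 nM, with a range from 50 nM to 400 nM.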

Compound 4, half-maximal effective concentration: 131 nM
The estimate for compound 4 lay 1.0-fold (0.00 log units) below the measured number; measured number inside the range.
By their numbers in this assay, from the lowest: compounds 3, 1 and 4 (each within the scatter of the next); then compound 2.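

Going from 3-methylphenyl to 3-(trifluoromethoxy)phenyl replaces 1 heavy atom with 5 and adds a hydrogen-bond acceptor, yet in this assay this gives a 1.5-fold higher number from compound 3 to compound 4 (0.16 log units; within the scatter), and exchanging trifluoromethyl for trifluoromethoxy gives a 1.3-fold higher number from compound 1 to compound 4 (0.11 log units; within the scatter), so methyl, trifluoromethyl and trifluoromethoxy on this aromatic carbon cannot be told apart by their numbers. The contrast with the 2-(trifluoromethyl)phenyl group also holds for this new group, with a 5.4-fold lower number from compound 2 to compound 4 (0.73 log units; beyond the scatter), so all three 3-substituted phenyl compounds now stand clearly apart from compound 2 and the earlier picture no longer rests on methyl and trifluoromethyl alone. Nothing in the material shown explains why this carbon accepts such different groups with so little change in the number.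

As far as these compounds go, whether this flat picture extends to groups of another kind on the same carbon, such as an amine or a carboxylic acid, remains open. From the compounds shown here alone, it is also open whether the higher number of compound 2 is specific to trifluoromethyl or would appear with other groups on a 2-substituted phenyl ring.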